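Aryl swap on the hydrazone of compound 1

A few compounds are considered here, and "the series" means these few. Any claim that something is new, unique, unknown or untested is made for them only; others in the source may bear on it.

Compound 1 `COc1cc(/C=N/NC(=O)CCN2CCN(c3ccnc4cc(Cl)ccc34)CC2)ccc1O` stands highest of the two numbers in a physicochemical assay for inhibition, read by spectrophotometry, with a stated time of 24 h, tested at 2.5 mM (a lower number here means less inhibition, a higher number more inhibition at the concentration tested (going by the name of the read-out)), giving 50.7%; compound 2 `NNC(=O)CCN1CCN(c2ccnc3cc(Cl)ccc23)CC1` gives 21.7%, the step being a number 29 percentage points lower from compound 1 to compound 2 (beyond the scatter). Compound 3 `CN(C)c1ccc(/C=N/NC(=O)CCN2CCN(c3ccnc4cc(Cl)ccc34)CC2)cc1` differs from compound 1 by 4-(dimethylamino)phenyl in place of 4-hydroxy-3-methoxyphenyl on a carbon with a double bond to nitrogen. Going by the values given here, the single measured step removes the whole arylidene group rather than exchanging one aryl group for another, so it bears on the present change only loosely; no measured pair shows an aryl-for-aryl swap. Compound 3 is expected to stay near compound 1, a step of a number 7.7 percentage points lower from compound 1 to compound 3 (within the scatter) not beyond the scatter. The estimate for compound 3 is 43%, range 22% to 64%.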

Compound 3, a percentage reported as inhibition, at one concentration (the size of the read-out at that concentration, not a potency): 94.2%
Beside the measured number, compound 3's estimate is 51.2 percentage points below it, and the stated range ends below it.
By their numbers in this assay, from the lowest: compound 2; then compound 1; then compound 3.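

Exchanging one aryl group for another on a carbon with a double bond to nitrogen gives a number 43.5 percentage points higher from compound 1 to compound 3 (beyond the scatter) in this assay, so the outcome depends on which aryl group is present, not only on whether one is there. Set against the unsubstituted hydrazide, 4-(dimethylamino)phenyl gives a number 72.5 percentage points higher from compound 2 to compound 3 (beyond the scatter), and this group carries the series well past compound 1. No measured evidence here explains the effect of the swap.

The step changes both aryl substituents at once, leaving open whether the entering dimethylamino group or the departing hydroxy and methoxy groups matter more. A 4-aminophenyl or 4-methoxyphenyl group in this place would separate the two.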